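Swapping the amide tail of compound 3 for a cyclohexyl ring

The source may report more compounds than this note shows. Statements on the series, on what has been measured and on what is new or still open speak of the compounds shown alone.

Three compounds here share a core carrying two amide groups, and each was examined in an ADME assay on MRC5 cells (Homo sapiens) for inhibition, with a stated time of 72 h; on this read-out higher numbers stand for an effect only at larger amounts of compound and lower numbers for an effect already at smaller amounts. Compound 1 `CO[C@H]1CC[C@H](NC(=O)c2n[nH]cc2NC(=O)c2ncoc2-c2ccccc2)CC1` gives 28000 nM. Compound 2 `CO[C@H]1CC[C@H](NC(=O)c2n[nH]cc2NC(=O)c2ccc(-c3ccccc3)o2)CC1` gives 100 nM. Compound 3 `COCCNC(=O)c1n[nH]cc1NC(=O)c1c(OC)cccc1OC` differs from both in what hangs on each amide, and in this assay compound 3 reaches only the limit of > 50000 nM, which is a boundary of the measurement and not a number. Of the three values shown, one sits at that boundary (the limit of > 50000 nM in this assay, at which 1 of the 3 values shown sits), so the position of compound 3 is known only as lying at or beyond it.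

Compound 4 `COc1cccc(OC)c1C(=O)Nc1c[nH]nc1C(=O)NC1CCCCC1` has not yet been measured. It keeps everything of compound 3 except one change: cyclohexyl in place of 2-methoxyethyl on an amide-type nitrogen. The two measured compounds carrying a ring on that amide nitrogen, compound 1 and compound 2, both return numbers rather than limits, but neither differs from compound 3 in a single place, so their values show only where they stand, not what this particular change does. The expectation for compound 4 is therefore cautious: a step from compound 3 of an at least 1.6-fold lower number from compound 3 to compound 4 (0.22 log units; that floor lies within the scatter) is expected, small and uncertain in direction. In this assay compound 4 is estimated to give 30000 nM, within a range from 8000 nM to 60000 nM.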

Compound 4, half-maximal effective concentration: 35000 nM
The estimate for compound 4 lay 1.2-fold (0.07 log units) below the measured number; measured number inside the range.
By their numbers in this assay, from the lowest: compound 2; then compounds 1 and 4 (each within the scatter of the next). At a limit, above all of these: compound 3.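

Within the data shown here, this is the first pair here that differs in one place only, so it gives the first direct reading of a change on this amide-type nitrogen: in this assay, cyclohexyl in place of 2-methoxyethyl gives an at least 1.4-fold lower number from compound 3 to compound 4 (0.15 log units; that floor lies within the scatter). That figure is a floor and not an exact size, because compound 3 sits at a limit of the assay and not at a number: the limit of > 50000 nM in this assay, at which 1 of the 4 values shown sits.

As far as these compounds go, since the floor lies within the scatter, the true size of the step stays unknown. Compound 4 at 35000 nM now gives later changes at this position a real number to be compared with, which compound 3 could not offer.

What the compounds shown leave open is how other groups on this nitrogen would read, such as a chain ending in an amine, a carboxylic acid or a longer carbon chain. Among these compounds, they also leave open whether the same swap from 2-methoxyethyl to cyclohexyl would give a similar step in compounds with a different group on the other amide, such as the one in compound 1 or compound 2.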